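This account rests on a few compounds, and the source may have more. Where it says the series, first, only, none or still open, it means among the compounds named here.

Compound 3 `COc1ccc(F)cc1CNCCCNc1ccnc2cc(CC3CCCCC3)ccc12` stands lowest of the three compounds measured in an ADME assay on HepG2 cells (Homo sapiens) for cytotoxicity, read by luminescence, CellTiter-Glo and ATP content, with a stated time of 72 h; on this read-out higher numbers stand for an effect only at larger amounts of compound and lower numbers for an effect already at smaller amounts: compound 3 gives 1830 nM. Compound 1 `COc1cccc(Oc2ccc3c(NCCCNCc4cc(F)ccc4OC)ccnc3c2)c1` gives 7100 nM in this assay, and compound 2 `COc1ccc(-c2ccc3c(NCCCNCc4cc(F)ccc4OC)ccnc3c2)cc1` gives 5960 nM. The steps of a 3.9-fold lower number from compound 1 to compound 3 (0.59 log units; beyond the scatter) and a 3.3-fold lower number from compound 2 to compound 3 (0.51 log units; beyond the scatter) both lie beyond the scatter, whereas the step of a 1.2-fold lower number from compound 1 to compound 2 (0.08 log units; within the scatter) does not. Compound 4 `COc1ccc(F)cc1CNCCCNc1ccnc2cc(-c3ccc(C(F)(F)F)cc3)ccc12` differs from compound 3 in one place: 4-(trifluoromethyl)phenyl in place of cyclohexylmethyl on an aromatic carbon. The measured steps that bear on this change are the two in which cyclohexylmethyl entered in place of 3-methoxyphenoxy or of 4-methoxyphenyl, both modest and both toward a lower number. Read in the opposite direction, the exchange of cyclohexylmethyl for an aromatic ring on this carbon would be expected to raise the number in this assay. The 4-(trifluoromethyl)phenyl group is not the same as 4-methoxyphenyl or 3-methoxyphenoxy, so the size is uncertain, but a modest rise is the expectation, that is the step of a 2.2-fold higher number from compound 3 to compound 4 (0.34 log units; beyond the scatter). Compound 4 is therefore expected to give about 4000 nM in this assay, with a range from 2000 nM to 9000 nM.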

Compound 4, half-maximal effective concentration: 5190 nM
Compound 4: middle estimate off by 1.3-fold (0.11 log units), on the low side, and the stated range covers the measured number.
By their numbers in this assay, from the lowest: compound 3; then compounds 4, 2 and 1 (each within the scatter of the next).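

The step of a 2.8-fold higher number from compound 3 to compound 4 (0.45 log units; beyond the scatter) in this assay shows that the gap seen earlier for cyclohexylmethyl also appears against an aromatic group that carries trifluoromethyl rather than methoxy, so it is not confined to the two methoxy-bearing groups. The other two steps, a 1.1-fold lower number from compound 2 to compound 4 (0.06 log units; within the scatter) and a 1.4-fold lower number from compound 1 to compound 4 (0.14 log units; within the scatter), both lie within the scatter: trifluoromethyl in place of methoxy shows no measurable change here, and among the listed compounds 4-(trifluoromethyl)phenyl, 4-methoxyphenyl and 3-methoxyphenoxy cannot be told apart, with compound 3 alone standing apart and no listed compound going against this. Nothing available here gives a reason for this pattern.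

The compounds shown leave open whether the lower number of compound 3 goes with its non-aromatic ring or with the methylene link of cyclohexylmethyl, a question that a benzyl group or a cyclohexyl group bound directly to the same aromatic carbon would address. They also leave open how the number responds to a group of another kind at this position, such as an amine or a carboxylic acid on the ring.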